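Aryl change on the sulfonamide of compound 3

A few compounds are considered here, and "the series" means these few. Any claim that something is new, unique, unknown or untested is made for them only; others in the source may bear on it.

Measured so far in a functional assay on HL-60 cells (Homo sapiens) for antiproliferative activity, read by MTT assay, with a stated time of 72 h; on this read-out higher numbers stand for weaker inhibition and lower numbers for stronger inhibition:
compound 1, `CN(C(=O)c1ccc(Cl)cc1)c1ccc2[nH]c(-c3n[nH]c4ccccc34)cc2n1`, 450 nM
compound 2, `COc1ccc(C(=O)N(C)c2ccc3[nH]c(-c4n[nH]c5ccccc45)cc3n2)cc1`, 3320 nM
compound 3, `Cc1ccc(S(=O)(=O)N(C)c2ccc3[nH]c(-c4n[nH]c5ccccc45)cc3n2)cc1`, 3030 nM

Compound 3 gives the second highest of the three numbers; its nearest neighbour is compound 2, and the two lie within the scatter, while compound 1 sits well apart, the step being a 6.7-fold higher number from compound 1 to compound 3 (0.83 log units; beyond the scatter). Compound 4, `CN(c1ccc2[nH]c(-c3n[nH]c4ccccc34)cc2n1)S(=O)(=O)c1cccc([N+](=O)[O-])c1`, has not been measured. It differs from compound 3 in one place: 3-nitrophenyl in place of 4-methylphenyl on a sulfonyl sulfur.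

For the measured compounds named here, only one measured step alters a substituent on the outer aromatic ring: a 7.4-fold higher number from compound 1 to compound 2 (0.87 log units; beyond the scatter), and that ring hangs on a carbonyl, not a sulfonyl, with a different pair of groups. The step of a 1.1-fold lower number from compound 2 to compound 3 (0.04 log units; within the scatter) shows that the carbonyl-to-sulfonyl exchange itself changed little. Going by the values given here, no measured step involves a nitro group, so the direction for compound 4 is uncertain; a change of modest size in either direction, or none beyond the scatter, seems plausible. The step is therefore estimated as a 1.2-fold lower number from compound 3 to compound 4 (0.08 log units; within the scatter). Compound 4 is expected to give about 2500 nM, with a range from 800 nM to 8000 nM.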

Compound 4, half-maximal inhibitory concentration: 3660 nM
Compound 4: the middle estimate sits 1.5-fold (0.17 log units) below what was measured; the measured number falls inside the stated range.
By their numbers in this assay, from the lowest: compound 1; then compounds 3, 2 and 4 (each within the scatter of the next).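

In this assay, for the compounds shown here, the sulfonyl sulfur carries 3-nitrophenyl as readily as 4-methylphenyl: a 1.2-fold higher number from compound 3 to compound 4 (0.08 log units; within the scatter) is the first measured change to the aryl group on a sulfonyl, and it stays inside the scatter. On the carbonyl compounds, by contrast, exchanging one substituent on the outer ring gave a step beyond the scatter, a 7.4-fold higher number from compound 1 to compound 2 (0.87 log units; beyond the scatter), so the two aryl positions need not respond alike, though that contrast rests on different pairs of groups. Nothing measured here bears on why the sulfonyl exchange makes so little difference.

The compounds shown leave open whether 4-chlorophenyl on the sulfonyl sulfur would bring the number near that of compound 1 at 450 nM. They also leave open whether an amine or a carboxylic acid on this ring would stay within the scatter of compound 3.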